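The compounds below may be only part of what the source reports. "The series", "measured", "known", "first", "only" and "open" are said of these compounds alone.

compound 1 `CCN(CC)c1ccc2cc(C(=O)c3ccc(N4CCN(C(=O)CN5CCN(C(=O)/C=C/c6ccccc6)CC5)CC4)cc3)oc2c1` — 1140 nM
compound 2 `CCN(CC)c1ccc2cc(C(=O)c3ccc(N4CCN(C(=O)CN5CCN(S(=O)(=O)C6CC6)CC5)CC4)cc3)oc2c1` — 15300 nM
compound 3 `CCN(CC)c1ccc2cc(C(=O)c3ccc(N4CCN(C(=O)CN5CCN(S(=O)(=O)c6ccc(F)cc6)CC5)CC4)cc3)oc2c1` — > 40000 nM

Of the compounds shown here, three sharing the core of compound 1 have been measured in a functional assay on SGC-7901 cells (Homo sapiens) for cytotoxicity, read by MTT assay, with a stated time of 48 h; a higher number here means a weaker inhibitor, a lower number a stronger inhibitor. Compound 1 `CCN(CC)c1ccc2cc(C(=O)c3ccc(N4CCN(C(=O)CN5CCN(C(=O)/C=C/c6ccccc6)CC5)CC4)cc3)oc2c1` gives 1140 nM. Compound 2 `CCN(CC)c1ccc2cc(C(=O)c3ccc(N4CCN(C(=O)CN5CCN(S(=O)(=O)C6CC6)CC5)CC4)cc3)oc2c1` gives 15300 nM. For compound 3 `CCN(CC)c1ccc2cc(C(=O)c3ccc(N4CCN(C(=O)CN5CCN(S(=O)(=O)c6ccc(F)cc6)CC5)CC4)cc3)oc2c1` only an assay limit is recorded, > 40000 nM, a limit also noted as the limit of > 40000 nM in this assay, at which 1 of the 3 values shown sits. Compound 3 thus stands weakest of the three, since an at least 35-fold higher number from compound 1 to compound 3 (1.54 log units; beyond the scatter) and an at least 2.6-fold higher number from compound 2 to compound 3 (0.41 log units; beyond the scatter) both lie beyond the scatter. Compound 4 `CCN(CC)c1ccc2cc(C(=O)c3ccc(N4CCN(C(=O)CN5CCN(Cc6ccc(F)c(F)c6)CC5)CC4)cc3)oc2c1` differs from compound 3 by 3,4-difluorobenzyl in place of (4-fluorophenyl)sulfonyl on an amine nitrogen in a ring. For the measured compounds named here, no measured step exchanges a sulfonyl for a benzyl; the steps of a 13-fold higher number from compound 1 to compound 2 (1.13 log units; beyond the scatter) and an at least 35-fold higher number from compound 1 to compound 3 (1.54 log units; beyond the scatter) show only that both sulfonyls weaken relative to the carbonyl of compound 1. Compound 4 is therefore expected to give a lower number than compound 3, an at least 5.0-fold lower number from compound 3 to compound 4 (0.69 log units; beyond the scatter), estimated at 8000 nM within 1500 nM to 40000 nM.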

Compound 4, half-maximal inhibitory concentration: 1780 nM
Compound 4: the middle estimate sits 4.5-fold (0.65 log units) above what was measured; the range from low to high includes it.
By their numbers in this assay, from the lowest: compounds 1 and 4 (each within the scatter of the next); then compound 2. At a limit, above all of these: compound 3.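

In this assay, the exchange on this ring nitrogen shows that a group with neither carbonyl nor sulfonyl can restore a low number: 3,4-difluorobenzyl gives an at least 22-fold lower number from compound 3 to compound 4 (1.35 log units; beyond the scatter) and an 8.6-fold lower number from compound 2 to compound 4 (0.93 log units; beyond the scatter). Against (2-phenylethenyl)carbonyl the same group gives a 1.6-fold higher number from compound 1 to compound 4 (0.19 log units; within the scatter), so the carbonyl is not required to reach this level. For compound 3 the value is a limit, so its step has no fixed size: the limit of > 40000 nM in this assay, at which 1 of the 4 values shown sits.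

The compounds shown leave open whether the two fluorines on the benzyl matter, and how a plain benzyl, a methoxybenzyl or a simple alkyl chain on this nitrogen would read.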